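Allyl in place of ethoxymethyl on a shared core

A few compounds are considered here, and "the series" means these few. Any claim that something is new, unique, unknown or untested is made for them only; others in the source may bear on it.

Three compounds were measured in a functional assay for inhibition of Polyunsaturated fatty acid 5-lipoxygenase (Homo sapiens), in the absence of a further agent; a lower number here means a stronger inhibitor, a higher number a weaker inhibitor:
compound 1, `COc1ccc(Cc2oc3c(Cl)cc(C(C)(C)C)c(O)c3c2C)cc1`, gives 99 nM;
compound 2, `COc1ccc(Cc2oc3c(Cl)ccc(O)c3c2C)cc1`, gives 376 nM;
compound 3, `CCOCc1cc(Cl)c2oc(Cc3ccc(OC)cc3)c(C)c2c1O`, gives 291 nM.

Among these three numbers compound 3 stands second highest. Its nearest neighbour is compound 2, with a 1.3-fold lower number from compound 2 to compound 3 (0.11 log units; within the scatter), a gap within the scatter. The one clear separation is a 2.9-fold higher number from compound 1 to compound 3 (0.47 log units; beyond the scatter), where ethoxymethyl on an aromatic carbon replaces tert-butyl.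

Compound 4, `C=CCc1cc(Cl)c2oc(Cc3ccc(OC)cc3)c(C)c2c1O`, differs from compound 3 by vinyl in place of ethoxy on a saturated chain carbon bound to an aromatic carbon; cut one bond further out, the change reads ethoxymethyl to allyl. Going by the values given here, no measured step exchanges one chain for another there. The two steps that touch the ethoxymethyl group both end at compound 3: a 1.3-fold lower number from compound 2 to compound 3 (0.11 log units; within the scatter) shows that adding the group barely moved the number, and a 2.9-fold higher number from compound 1 to compound 3 (0.47 log units; beyond the scatter) shows a modest rise from the tert-butyl compound. With nothing that alters the chain itself, compound 4 is expected to sit close to compound 3 in this assay, and the estimated step is a 1.1-fold lower number from compound 3 to compound 4 (0.05 log units; within the scatter). Compound 4 is estimated at 260 nM, with a range from 100 nM to 650 nM.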

Compound 4, half-maximal inhibitory concentration: 20 nM
Estimate against measurement, compound 4: 13-fold (1.11 log units) above; measured number below the stated range.
By their numbers in this assay, from the lowest: compound 4; then compound 1; then compounds 3 and 2 (each within the scatter of the next).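

In this assay, going by these compounds alone, this position on an aromatic carbon turns out to respond strongly to the choice of chain, which the earlier compounds did not reveal: ethoxymethyl had stayed within the scatter of hydrogen, whereas allyl gives a large drop against both ethoxymethyl (a 15-fold lower number from compound 3 to compound 4 (1.16 log units; beyond the scatter)) and hydrogen (a 19-fold lower number from compound 2 to compound 4 (1.27 log units; beyond the scatter)). Allyl also improves on tert-butyl (a 5.0-fold lower number from compound 1 to compound 4 (0.69 log units; beyond the scatter)), so compound 4 is the strongest inhibitor of the four, with its steps to all the others beyond the scatter. Nothing shown here explains why vinyl in place of ethoxy on the saturated chain carbon has so large an effect.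

Going by these compounds, it remains open whether the double bond matters or whether the loss of the ether oxygen is enough, a question that a saturated propyl chain at this position would address. On these data alone, whether a longer chain, such as butenyl, would hold or lose the gain also remains unknown.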